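This account rests on a few compounds, and the source may have more. Where it says the series, first, only, none or still open, it means among the compounds named here.

Compound 1 `CCCCCCCCCNC(=O)[C@H]1OC(n2cnc3c(N)ncnc32)[C@H](O)[C@@H]1O` gives 31 nM in an assay on cell membranes for binding affinity to 2-oxoglutarate receptor 1 (Rattus norvegicus), read by radioligand binding; on this read-out lower numbers stand for stronger inhibition and higher numbers for weaker inhibition. Compound 2 `CC(=O)NCCNC(=O)[C@H]1OC(n2cnc3c(N)ncnc32)[C@H](O)[C@@H]1O` gives 46 nM in this assay, and compound 2 sits within the scatter of compound 1, as the step of a 1.5-fold higher number from compound 1 to compound 2 (0.17 log units; within the scatter) shows. Compound 3 `COc1ccc(CNC(=O)[C@H]2OC(n3cnc4c(N)ncnc43)[C@H](O)[C@@H]2O)cc1OC` carries 3,4-dimethoxyphenyl in place of acetamidomethyl on a saturated chain carbon bound to an amide-type nitrogen. Among the measured compounds shown here, the single measured step exchanged one chain group for another, two bonds along the chain from an amide-type nitrogen, and stayed within the scatter; no measured step brings in an aromatic ring, so the step is expected to be a 1.1-fold higher number from compound 2 to compound 3 (0.04 log units; within the scatter), not beyond the scatter. Compound 3 is estimated at 50 nM, between 15 nM and 180 nM.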

Compound 3, inhibition constant: 140 nM
Compound 3: the middle estimate sits 2.8-fold (0.45 log units) below what was measured; measured number inside the range.
By their numbers in this assay, from the lowest: compounds 1 and 2 (each within the scatter of the next); then compound 3.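

In this assay the place on a saturated chain carbon bound to an amide-type nitrogen proves sensitive to the group it carries, with 3,4-dimethoxyphenyl giving a 3.0-fold higher number from compound 2 to compound 3 (0.48 log units; beyond the scatter) and a 4.5-fold higher number from compound 1 to compound 3 (0.65 log units; beyond the scatter) as modest steps, both beyond the scatter. Inhibition thus weakens when a six-membered aromatic ring of carbon only enters here, whereas the exchange of one open chain for another did not move the number beyond the scatter. Nothing at hand explains this shift. The compounds shown leave open whether the ring or its two methoxy groups carry the change, and how a plain phenyl, an amine or a carboxylic acid would read at this place.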